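Shortening the propyl chain of a weak inhibitor series

A few compounds are considered here, and "the series" means these few. Any claim that something is new, unique, unknown or untested is made for them only; others in the source may bear on it.

Measured compounds:
compound 1 `CCCc1nc(C)c2ccnc(Nc3cc[nH]n3)n12`: 25000 nM
compound 2 `CCCc1nc(C)c2c(C(C)C)cnc(Nc3cc[nH]n3)n12`: > 48000 nM (a limit, not a number)

Among the compounds with values here, in a functional assay for inhibition, with Homo sapiens as the target (a higher number here means a weaker inhibitor, a lower number a stronger inhibitor), compound 1 gives 25000 nM, the only actual number in the set. For compound 2 the result is a limit of this assay rather than a number, > 48000 nM. The set therefore holds (the limit of > 48000 nM in this assay, at which 1 of the 2 values shown sits).

Within the data shown here, the one measured step, an at least 1.9-fold higher number from compound 1 to compound 2 (0.28 log units; that floor lies within the scatter), puts isopropyl in place of hydrogen on an aromatic carbon of the shared core. It concerns a ring position, not the chain, and its floor sits within the scatter, so it gives no direction for a change on the propyl group.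

Compound 3 `CCc1nc(C)c2ccnc(Nc3cc[nH]n3)n12` differs from compound 1 by hydrogen in place of methyl on a saturated chain carbon, two bonds along the chain from an aromatic carbon. Among the measured compounds shown here, no measured step touches this chain, and the core is otherwise the same as in compound 1. The expectation is therefore a step of a 1.2-fold higher number from compound 1 to compound 3 (0.08 log units; within the scatter), nothing beyond the usual scatter, with a real chance that this assay returns only a limit. Compound 3 is estimated at 30000 nM, in the range 12000 nM to 70000 nM.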

Compound 3, half-maximal inhibitory concentration: 13000 nM
Compound 3: middle estimate off by 2.3-fold (0.36 log units), on the high side, and the stated range covers the measured number.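

In this assay, within the data shown here, the first measured change on this chain, propyl to ethyl, gives a 1.9-fold lower number from compound 1 to compound 3 (0.28 log units; within the scatter) and so does not separate the two chains. At this level of activity, the full propyl group is therefore not shown to be needed, since ethyl on the shared core serves within the scatter and no loss appears at this position. Compound 3 also returns a number and compound 2 remains the only limit in the set, so the chain change can be read as a step, whereas the isopropyl change has only a floor: the limit of > 48000 nM in this assay, at which 1 of the 3 values shown sits.

As far as these compounds go, whether a methyl group, a longer chain such as butyl, or a chain ending in an amine would move the number beyond the scatter remains open, so no trend along the chain can be drawn from propyl and ethyl alone. Also open, from the compounds shown here alone, is whether isopropyl in place of hydrogen on an aromatic carbon would read any differently on the ethyl compound, where the starting number would be that of compound 3, 13000 nM in this assay.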